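Shortening the butyl chain: compound 2 to compound 3

The compounds below may be only part of what the source reports. "The series", "measured", "known", "first", "only" and "open" are said of these compounds alone.

Measured in a functional assay on MCF7 cells (Homo sapiens) for cytotoxicity, read by MTT assay, with a stated time of 72 h; a lower number here means a stronger inhibitor, a higher number a weaker inhibitor:
Compound 1 `O=C1c2c[n+]([O-])c3ccccc3c2C(=O)c2c1c1ccccc1n2Cc1cn(C[C@H](O)CO)nn1`: > 1000 nM
Compound 2 `CCCCN1CCN(CCCCn2c3c(c4ccccc42)C(=O)c2c[n+]([O-])c4ccccc4c2C3=O)CC1`: 6900 nM

The entry for compound 1, > 1000 nM, is a limit and not a number. Going by the values given here, compound 2, with 6900 nM, carries the only actual number in this assay, and the series offers no measured step between two compounds to scale from.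

Compound 3 `CCCN1CCN(CCCCn2c3c(c4ccccc42)C(=O)c2c[n+]([O-])c4ccccc4c2C3=O)CC1` differs from compound 2 in one place: hydrogen in place of methyl on a saturated chain carbon, three bonds along the chain from an amine nitrogen in a ring. This is hydrogen in place of methyl on a saturated chain carbon, three bonds along the chain from an amine nitrogen in a ring. Cut one bond further out, the same difference reads butyl to propyl.

Among the compounds with values here, with no measured step to draw on, the expectation in this assay is no shift beyond the usual scatter, in either direction. It is anchored on compound 2 with 6900 nM. The estimated change is a 1.1-fold lower number from compound 2 to compound 3 (0.03 log units; within the scatter), which is expected to stay within that scatter. For compound 3 the expected value is 6500 nM, with an estimated range of 2800 nM to 15000 nM.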

Compound 3, half-maximal inhibitory concentration: 1280 nM
The estimate for compound 3 lay 5.1-fold (0.71 log units) above the measured number, outside the stated range (below it).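

In this assay the series now has its first readable step, a 5.4-fold lower number from compound 2 to compound 3 (0.73 log units; beyond the scatter) for hydrogen in place of methyl on a saturated chain carbon, three bonds along the chain from an amine nitrogen in a ring. Read as butyl to propyl, this change lies beyond the scatter, so this position responds to the removal of a single carbon, which compound 2 alone, as the only number in the series until now, could not show. Compound 1 remains a limit, and its step to compound 3 cannot be read: the limit of > 1000 nM in this assay, at which 1 of the 3 values shown sits.

As far as these compounds go, compound 2 and compound 3 give a single step and no trend, so it stays open whether the number keeps falling with ethyl or methyl in place of propyl, or how a longer chain such as pentyl would read. Also open, from the compounds shown here alone, is whether a hydroxyl group or a carboxylic acid on the propyl chain would keep or lose the lower number seen for compound 3.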